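Aryl ether series: cyano for chloro on compound 2

The source may report more compounds than this note shows. Statements on the series, on what has been measured and on what is new or still open speak of the compounds shown alone.

Working notes. Going by the values given here, the three compounds measured so far share one core, varied at the ether oxygen. Compound 1 `O=C1CSc2cc(OCC3CCCCC3)ccc2N1` carries a cyclohexylmethyl group and in an assay on isolated protein for inhibition of Amine oxidase [flavin-containing] A (Homo sapiens), read by fluorescence and spectrophotometry, with a stated time of 20 min (a lower number here means a stronger inhibitor, a higher number a weaker inhibitor), compound 1 gives 1170 nM. Compound 2 `O=C1CSc2cc(OCc3ccc(Cl)cc3)ccc2N1`, with a chlorobenzyl group, gives 24400 nM in this assay, and compound 3 `O=C1CSc2cc(O)ccc2N1`, the free phenol, gives 19200 nM. Compound 2 therefore has the highest number of the three; the values of compound 2 and compound 3 lie within the scatter of each other, while compound 1 sits far lower, beyond the scatter.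

Compound 4 `N#Cc1ccc(COc2ccc3c(c2)SCC(=O)N3)cc1` differs from compound 2 in one place: cyano in place of chloro on an aromatic carbon. Among the compounds with values here, no measured pair isolates this change, so the size of the step is unknown; a small step in this assay, within the scatter in either direction, is expected, as the change keeps the benzyl ether of compound 2 and alters only the group at one aromatic carbon.

On that basis compound 4 is estimated at 20000 nM, with a range of 6000 nM to 60000 nM, and the expected step is a 1.2-fold lower number from compound 2 to compound 4 (0.09 log units; within the scatter).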

Compound 4, half-maximal inhibitory concentration: 714 nM
For compound 4 the middle estimate is 28-fold (1.45 log units) above the measured one; the measured number lies below the stated range.
By their numbers in this assay, from the lowest: compounds 4 and 1 (each within the scatter of the next); then compounds 3 and 2 (each within the scatter of the next).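

In this assay, going by these compounds alone, cyano in place of chloro gives a 34-fold lower number from compound 2 to compound 4 (1.53 log units; beyond the scatter), the first step that isolates a single change. The benzyl ether is kept, so the group on this aromatic carbon, para to a large group, can by itself move the number well beyond the scatter. No evidence on the origin of this step is available.

From the compounds shown here alone, whether other groups on this aromatic carbon, such as an amine, a methoxy group or a carboxylic acid, would give a number like that of compound 4 or like that of compound 2 remains open. Also open, going by these compounds, is how the number would respond if the cyano group stood on a different carbon of the same ring.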